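The compounds below may be only part of what the source reports. "The series", "measured", "known", "first", "only" and "open" are said of these compounds alone.

Working notes on the series. Compound 3 `C#CCn1cc(C(=O)NC(CC(=O)Nc2ccccc2)c2ccccc2)c(=O)c2ccc(Cl)nc21` gives 4000 nM in a functional assay on HBL-100 cells (Homo sapiens) for cytotoxicity, read by MTT assay, with a stated time of 72 h; on this read-out higher numbers stand for weaker inhibition and lower numbers for stronger inhibition. Compound 1 `C#CCn1cc(C(=O)NC(CC(=O)Nc2ccccc2)c2ccccc2)c(=O)c2cc(F)c(Cl)nc21`, which carries an added fluoro group on the shared core, gives 9300 nM in this assay. Compound 2 `C#CCn1cc(C(=O)NC(CC(=O)Nc2ccccn2)c2ccccc2)c(=O)c2ccc(Cl)nc21`, with a pyridin-2-yl amide in place of the phenyl amide, reports only a limit in this assay, namely > 10000 nM; among the numbers shown it therefore stands apart as a limit rather than a value. Among the measured compounds shown here, two measured steps bear on the change ahead. On removal of the fluoro, a 2.3-fold lower number from compound 1 to compound 3 (0.37 log units; beyond the scatter). On exchange of the amide aryl, an at least 2.5-fold lower number from compound 2 to compound 3 (0.39 log units; beyond the scatter). Compound 4 `C#CCn1cc(C(=O)NC(CC(=O)Nc2ccccn2)c2ccccc2)c(=O)c2cc(F)c(Cl)nc21` has not been measured; it differs from compound 2 by fluoro in place of hydrogen on an aromatic carbon. This reverses the change seen in a 2.3-fold lower number from compound 1 to compound 3 (0.37 log units; beyond the scatter), so a modest rise in the number is expected for compound 4. Compound 2 already sits at the limit of > 10000 nM in this assay, at which 1 of the 3 values shown sits, so compound 4 is expected to return only the limit as well. The expected step is a step that the limit leaves unreadable from compound 2 to compound 4. Compound 4 is estimated at 20000 nM, between 10000 nM and 50000 nM.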

Compound 4, half-maximal inhibitory concentration: > 10000 nM
Compound 4 was reported as a limit; the forecaster's own chance of this, stated with the estimate: 85%; the middle value does not contradict the limit.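

In this assay, fluoro in place of hydrogen on an aromatic carbon, ortho to a chloro group, has now been placed on the pyridin-2-yl amide as well as the phenyl amide, but the step from compound 2 to compound 4 cannot be read, as both ends are limits. On the fluoro-bearing core, pyridin-2-yl in place of phenyl gives an at least 1.0-fold higher number from compound 1 to compound 4 (0.03 log units; that floor lies within the scatter), so a rise in the number from this exchange is not established on that core. The exchange was beyond the scatter only on the core without fluoro, and any difference between the two cores stays unresolved: the same change on two cores in this assay, an at least 2.5-fold lower number (0.39 log units; beyond the scatter) from compound 2 to compound 3 and an at least 1.0-fold lower number (0.03 log units; that floor lies within the scatter) from compound 4 to compound 1; the limit leaves it open whether they differ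

Going by these compounds, what fluoro does on the pyridin-2-yl amide stays open, with readings stopped at: the limit of > 10000 nM in this assay, at which 2 of the 4 values shown sit. Also open is what an amine in place of the chloro group would do to the number on either core.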